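Benzyl-side change from compound 2 to compound 4

A few compounds are considered here, and "the series" means these few. Any claim that something is new, unique, unknown or untested is made for them only; others in the source may bear on it.

In a functional assay on HL-60 cells (Homo sapiens) for inhibition, read by CCK-8 assay, with a stated time of 48 h, tested at 20 uM (a higher number here means more inhibition of growth at the concentration tested, a lower number less inhibition of growth), compound 2 (`COc1ccc(S(=O)(=O)Oc2ccccc2/C=C(\C#N)C(=O)Nc2nnc(Cc3cccc4ccccc34)s2)cc1`) gives 98%. That is level, within the scatter, with compound 1 (`COc1ccc(Cc2nnc(NC(=O)/C(C#N)=C/c3ccccc3OS(=O)(=O)c3ccc(OC)cc3)s2)cc1`) at 100% and far from compound 3 (`N#C/C(=C\c1ccccc1OS(=O)(=O)c1ccccc1[N+](=O)[O-])C(=O)Nc1nnc(Cc2cccc3ccccc23)s1`) at 23%. Compound 4 (`COc1ccc(S(=O)(=O)Oc2ccccc2/C=C(\C#N)C(=O)Nc2nnc(Cc3ccc(F)cc3)s2)cc1`) carries 4-fluorophenyl in place of naphthalen-1-yl on a saturated chain carbon bound to an aromatic carbon. Within the data shown here, the one measured change at this place is a number 2 percentage points lower from compound 1 to compound 2 (within the scatter). The large step of a number 75 percentage points lower from compound 2 to compound 3 (beyond the scatter) is on the sulfonyl sulfur, which stays unchanged here, so it bears only weakly. No step beyond the scatter is expected in this assay, and the estimated step is a number 6 percentage points lower from compound 2 to compound 4 (within the scatter). The estimate for compound 4 is 92%, with an expected range of 65% to 100%.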

Compound 4, percent growth inhibition at one concentration: 100%
Beside the measured number, compound 4's estimate is 8 percentage points below it; the range from low to high includes it.
By their numbers in this assay, from the lowest: compound 3; then compounds 2, 1 and 4 (each within the scatter of the next).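

The step of a number 2 percentage points higher from compound 2 to compound 4 (within the scatter) in this assay shows that this place keeps growth inhibition level with one aromatic ring in place of two, in the change from (naphthalen-1-yl)methyl to 4-fluorobenzyl. The step of no change at the digits printed from compound 1 to compound 4 (within the scatter) likewise shows fluoro in place of methoxy on an aromatic carbon reading level. No measurement bears on why these steps stay within the scatter.

Compounds 1, 2 and 4 all lie near full inhibition at a single concentration, so any difference among them stays hidden. As far as these compounds go, whether a benzyl group carrying a carboxylic acid or an amine holds this level remains open.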